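Notes on the aryl change, compound 3 to compound 4

The source may report more compounds than this note shows. Statements on the series, on what has been measured and on what is new or still open speak of the compounds shown alone.

Measured in an assay on mitochondria (strain BALB/c) for inhibition of glycerol-3-phosphate acyltransferase 1, mitochondrial (Mus musculus), read by scintillation counting, with a stated time of 10 min; on this read-out lower numbers stand for stronger inhibition and higher numbers for weaker inhibition:
compound 1 `CCCCCCCCS(=O)(=O)Nc1cc(-c2cccc(Cl)c2)ccc1C(=O)O`: 13800 nM
compound 2 `CCCCCCCCS(=O)(=O)Nc1cc(-c2ccccc2F)ccc1C(=O)O`: 47200 nM
compound 3 `CCCCCCCCS(=O)(=O)Nc1cc(/C=C/c2ccccc2)ccc1C(=O)O`: 38000 nM

Compound 3 holds the second highest of the three numbers; a 1.2-fold lower number from compound 2 to compound 3 (0.09 log units; within the scatter) lies within the scatter, whereas a 2.8-fold higher number from compound 1 to compound 3 (0.44 log units; beyond the scatter) lies beyond it. Compound 4 `CCCCCCCCS(=O)(=O)Nc1cc(CCc2ccc(OC)cc2)ccc1C(=O)O` differs from compound 3 by 2-(4-methoxyphenyl)ethyl in place of 2-phenylethenyl on an aromatic carbon. For the measured compounds named here, no measured step makes exactly this change. The related steps, a 3.4-fold higher number from compound 1 to compound 2 (0.53 log units; beyond the scatter), a 2.8-fold higher number from compound 1 to compound 3 (0.44 log units; beyond the scatter) and a 1.2-fold lower number from compound 2 to compound 3 (0.09 log units; within the scatter), show that varying the group at this carbon has so far moved the number only modestly in this assay. A step within or just beyond the scatter is therefore expected, with no firm direction; the estimated step is a 1.3-fold lower number from compound 3 to compound 4 (0.10 log units; within the scatter). Compound 4 is expected to give about 30000 nM in this assay, within 10000 nM to 90000 nM.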

Compound 4, half-maximal inhibitory concentration: 43000 nM
Compound 4: the middle estimate sits 1.4-fold (0.16 log units) below what was measured, within the range that was stated.
By their numbers in this assay, from the lowest: compound 1; then compounds 3, 4 and 2 (each within the scatter of the next).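

Exchanging 2-phenylethenyl for 2-(4-methoxyphenyl)ethyl removes the double bond outside aromatic rings and adds a hydrogen-bond acceptor, yet the result is only a 1.1-fold higher number from compound 3 to compound 4 (0.05 log units; within the scatter), and a 1.1-fold lower number from compound 2 to compound 4 (0.04 log units; within the scatter). Compound 1, with its 3-chlorophenyl group, stays apart from this cluster, at a 3.1-fold higher number from compound 1 to compound 4 (0.49 log units; beyond the scatter). No supporting data explain this flat response at this position.

The compounds shown do not separate the loss of the double bond from the gain of the methoxy group, so the two changes could each be silent or could offset each other. Going by these compounds, how an amine or a carboxylic acid on the aromatic ring of this group would read also remains open.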